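Five-membered ring in place of the phenyl: compound 4

The compounds below may be only part of what the source reports. "The series", "measured", "known", "first", "only" and "open" are said of these compounds alone.

For the measured compounds named here, compound 3 `Fc1ccc(-c2cc(-c3cnn(C4CCNCC4)c3)on2)c(Cl)c1` gives 220 nM in an assay on isolated protein for positive allosteric modulation of Neuronal acetylcholine receptor; alpha4/beta2 (Homo sapiens) (on this read-out lower numbers stand for an effect already at smaller amounts and higher numbers for an effect only at larger amounts of compound), the lowest of the three numbers so far. Compound 1 `CN(Cc1cc(-c2ccccc2Cl)no1)C(=O)C1CCNCC1` gives 350 nM, within the scatter of compound 3. Compound 2 `c1ccc(-c2cc(-c3cnn(C4CCNCC4)c3)on2)cc1` gives 100000 nM, far above it. Going by the values given here, the only measured step on the shared core, a 450-fold lower number from compound 2 to compound 3 (2.66 log units; beyond the scatter), shows how strongly the group at this position sets the number. Compound 4 `Clc1sccc1-c1cc(-c2cnn(C3CCNCC3)c2)on1` carries 2-chlorothiophen-3-yl in place of 2-chloro-4-fluorophenyl on an aromatic carbon; the chlorine stays, the six-membered carbon ring becomes a five-membered ring with one sulfur. Among the compounds with values here, no measured pair covers such a ring exchange, so the expectation leans on the retained chlorine and on compound 3 with 220 nM. The expected step, a 2.7-fold higher number from compound 3 to compound 4 (0.44 log units; beyond the scatter), is a small rise, not beyond the scatter. For compound 4 the expected value is 600 nM, with a range of 200 nM to 2500 nM.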

Compound 4, half-maximal effective concentration: 130 nM
The estimate for compound 4 lay 4.6-fold (0.66 log units) above the measured number, and the stated range ends above it.
By their numbers in this assay, from the lowest: compounds 4, 3 and 1 (each within the scatter of the next, the first and the last beyond it); then compound 2.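

A step of a 1.7-fold lower number from compound 3 to compound 4 (0.23 log units; within the scatter) shows that the six-membered carbon ring of 2-chloro-4-fluorophenyl can give way to the five-membered ring of 2-chlorothiophen-3-yl, with its sulfur and without the fluorine, and the number holds. The step of a 770-fold lower number from compound 2 to compound 4 (2.89 log units; beyond the scatter) is also large, so at this position the low number seen with a chlorine-bearing group does not depend on the six-membered ring. Open, going by these compounds, is whether the chlorine of 2-chlorothiophen-3-yl is needed, and how a methyl, a methoxy or an amine in its place would read. No measured property of these groups accounts for the result.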